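Swapping the urea's tert-butyl for pentyl in a sulfonylurea

A few compounds are considered here, and "the series" means these few. Any claim that something is new, unique, unknown or untested is made for them only; others in the source may bear on it.

Of the compounds shown here, three have been measured in a functional assay on HEK293 cells for antagonist activity at thromboxane A2 receptor (Homo sapiens), read by fluorescence and calcium flux; a higher number here means a weaker inhibitor, a lower number a stronger inhibitor. Compound 1 `CCCCCNC(=O)NS(=O)(=O)c1cc(C#N)ccc1Oc1ccccc1C` gives 2240 nM in this assay, and compound 2 `CCCCCNC(=O)NS(=O)(=O)c1cc(C#N)ccc1Oc1cccc(C)c1` gives 1330 nM. Going by the values given here, the only single change among them, a 1.7-fold lower number from compound 1 to compound 2 (0.23 log units; within the scatter), is a shift of the methyl on the phenyl ether. Compound 3 `Cc1ccc(Oc2ccc(C#N)cc2S(=O)(=O)NC(=O)NC(C)(C)C)cc1` gives 750 nM, the lowest of the three numbers; it lies within the scatter of compound 2 and beyond it relative to compound 1. Among the compounds with values here, compound 3 differs from the other two in both the methyl position and the group on the urea nitrogen, so no single step separates it from them.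

Compound 4 `CCCCCNC(=O)NS(=O)(=O)c1cc(C#N)ccc1Oc1ccc(C)cc1` is the unmeasured target. The change from compound 3 is pentyl in place of tert-butyl on an amide-type nitrogen. Within the data shown here, no measured step covers this exchange: compounds 1 and 2 carry the pentyl already, but each also carries a different methyl position, so their values can only show that pentyl ureas have so far given somewhat higher numbers than compound 3. On that basis the step of a 1.3-fold higher number from compound 3 to compound 4 (0.12 log units; within the scatter) is expected to be small, possibly a modest rise, but not clearly beyond the scatter. Compound 4 is therefore estimated at 1000 nM, with a likely range from 400 nM to 2500 nM.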

Compound 4, half-maximal inhibitory concentration: 900 nM
Compound 4: middle estimate off by 1.1-fold (0.05 log units), on the high side; low and high end bracket the measured number.
By their numbers in this assay, from the lowest: compounds 3, 4, 2 and 1 (each within the scatter of the next, the first and the last beyond it).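

In this assay, the exchange of tert-butyl for pentyl on the amide-type nitrogen gives a 1.2-fold higher number from compound 3 to compound 4 (0.08 log units; within the scatter) with 4-methylphenyl held constant, so this first direct comparison of the two groups does not tell them apart. Going by these compounds alone, with pentyl held constant, the methyl position can now be read more fully: 4-methylphenyl in place of 3-methylphenyl gives a 1.5-fold lower number from compound 2 to compound 4 (0.17 log units; within the scatter) and does not separate those two compounds, while 4-methylphenyl in place of 2-methylphenyl gives a 2.5-fold lower number from compound 1 to compound 4 (0.40 log units; beyond the scatter) as the only new step that clears the usual scatter. No information is available to explain either the match between tert-butyl and pentyl or the step between the two methylphenyl groups.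

Going by these compounds, these compounds compare tert-butyl and pentyl only alongside 4-methylphenyl, so it remains open whether the exchange would read the same alongside 2-methylphenyl or 3-methylphenyl. They also leave open how the number would respond to a longer chain, a cyclohexyl ring or a chain ending in a carboxylic acid on the same nitrogen.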